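A Formyl-to-Hydroxyethyl Swap Carried to a Second Core

The source may hold more compounds than are shown below. What is called first, only, known or untested is meant among the compounds shown, and "the series" means these compounds.

Three compounds have been run in a functional assay on the whole organism with Mus musculus as the target; on this read-out higher numbers stand for an effect only at larger amounts of compound and lower numbers for an effect already at smaller amounts. Compound 1 `CN(c1ccncc1)n1cccc1C=O` carries a formyl group; in this assay compound 1 reached only the limit of the assay, > 20 mg/kg. Compound 3 `CC(O)c1cccn1N(C)c1ccncc1` bears a 1-hydroxyethyl instead, and in this assay compound 3 likewise reached only the limit, > 20 mg/kg. The step that the two limits leave unreadable from compound 1 to compound 3 consists of 1-hydroxyethyl in place of formyl on an aromatic carbon. Compound 2 `CN(c1ccncc1)n1ccc(C=O)c1` is made of the same atoms as compound 1 joined differently; the difference between the two cores is not broken down here. In this assay compound 2 also sits at the limit, > 20 mg/kg. All three values share one thing: the limit of > 20 mg/kg in this assay, at which 3 of the 3 values shown sit.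

Compound 4 `CC(O)c1ccn(N(C)c2ccncc2)c1` is not yet measured. It differs from compound 2 by 1-hydroxyethyl in place of formyl on an aromatic carbon, the same kind of change as from compound 1 to compound 3, though the place differs: two ring bonds from the ring nitrogen and from the ring atom that bears a group of 8 heavy atoms, rather than next to them. Because compound 2 stands at > 20 mg/kg and the earlier step that the two limits leave unreadable from compound 1 to compound 3 is unreadable, the expected step is a step that the limit leaves unreadable from compound 2 to compound 4. Compound 4 is estimated at 40 mg/kg, between 12 mg/kg and 200 mg/kg, most probably again only a limit.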

Compound 4, dose for half-maximal effect: 10 mg/kg
Compound 4: middle estimate off by 4.0-fold (0.60 log units), on the high side; the whole stated range lies above it.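

In this assay, putting 1-hydroxyethyl in place of formyl gives an at least 2.0-fold lower number from compound 2 to compound 4 (0.30 log units; that floor lies within the scatter), and compound 4 is the only one of the four compounds with a real number rather than a limit: the limit of > 20 mg/kg in this assay, at which 3 of the 4 values shown sit.

The floor of this step lies within the usual scatter and compound 2 has only a limit, which means the data leave the true size of the step unknown and do not prove a change beyond repeat-measurement noise. The same swap on the core of compound 1 cannot be read, with a limit at both ends, and the two steps therefore cannot be compared, so a lower number on one core does not show that the change carries over to the other.

Still open, on these data alone, is whether a longer chain such as 1-hydroxypropyl, or an amine such as aminomethyl, would do the same on this aromatic carbon, two ring bonds from the ring nitrogen. Also open, as far as these compounds go, is how much of the step comes from the hydroxyl of the 1-hydroxyethyl group and how much from its carbons.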